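The compounds below may be only part of what the source reports. "The series", "measured", "known", "first", "only" and "open" are said of these compounds alone.

Measured compounds:
compound 1 `CCc1ccc(C(=O)NC[C@H]2c3[nH]c4ccccc4c3C[C@H]3[C@H]4c5[nH]c6ccccc6c5C[C@@H]([C@H](C#N)N23)N4C)cc1` gives 3560 nM in a functional assay on HT-29 cells (Homo sapiens) for cytotoxicity, read by MTT assay, with a stated time of 72 h; on this read-out lower numbers stand for stronger inhibition and higher numbers for weaker inhibition;
compound 2 `CN1[C@@H]2c3[nH]c4ccccc4c3C[C@H]1[C@H](C#N)N1[C@@H](CNC(=O)c3cc4ccccc4s3)c3[nH]c4ccccc4c3C[C@@H]21` gives 640 nM in this assay.

Among the compounds with values here, compound 2 holds the lowest of the two numbers seen so far; its nearest neighbour is compound 1, and the single measured step, a 5.6-fold lower number from compound 1 to compound 2 (0.75 log units; beyond the scatter), separates them. Compound 3 `CN1[C@@H]2c3[nH]c4ccccc4c3C[C@H]1[C@H](C#N)N1[C@@H](CNC(=O)c3cc4ccccc4o3)c3[nH]c4ccccc4c3C[C@@H]21` is the next member of the series and has not yet been measured. It differs from compound 2 in one place only: 1-benzofuran-2-yl in place of 1-benzothiophen-2-yl on a carbonyl carbon. Within the data shown here, no measured step in this set changes a sulfur-containing ring into the oxygen-containing one, so the only step available, a 5.6-fold lower number from compound 1 to compound 2 (0.75 log units; beyond the scatter), concerns a different exchange on the same carbonyl carbon and bears on the present change only in showing that this position tolerates variation of the aryl group. Among the measured compounds shown here, because compound 2 gives 640 nM and the exchange in compound 3 has no measured counterpart, compound 3 is expected to bring no step beyond the scatter, a 1.1-fold higher number from compound 2 to compound 3 (0.04 log units; within the scatter). Compound 3 is therefore estimated at 700 nM in this assay, with a plausible range from 250 nM to 2000 nM.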

Compound 3, half-maximal inhibitory concentration: 850 nM
For compound 3 the middle estimate is 1.2-fold (0.08 log units) below the measured one, within the range that was stated.
By their numbers in this assay, from the lowest: compounds 2 and 3 (each within the scatter of the next); then compound 1.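

In this assay, moving from the sulfur-containing 1-benzothiophen-2-yl to the oxygen-containing 1-benzofuran-2-yl on the carbonyl carbon gives a 1.3-fold higher number from compound 2 to compound 3 (0.12 log units; within the scatter) and so leaves the two compounds indistinguishable in this assay. The lower number seen earlier is therefore not tied to 1-benzothiophen-2-yl alone, since replacing 4-ethylphenyl with 1-benzofuran-2-yl also gives a step beyond the scatter, a 4.2-fold lower number from compound 1 to compound 3 (0.62 log units; beyond the scatter) in this series of three. Nothing available here explains why the two ring systems behave alike or why both stand apart from 4-ethylphenyl.

The compounds shown leave open whether this tolerance extends to a third ring atom, as in 1H-indol-2-yl, where a ring nitrogen bearing hydrogen would take the place of the sulfur or oxygen. They also leave open what a plain phenyl group without the ethyl chain would give on the same carbonyl carbon, and whether a carboxylic acid or an amine on the 1-benzofuran-2-yl group would keep the number in the same range.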